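The source may report more compounds than this note shows. Statements on the series, on what has been measured and on what is new or still open speak of the compounds shown alone.

Series notes. The shared core carries an amide on one side and a sulfonamide on the other, and the three measured compounds differ only in the aryl group on the carbonyl carbon. In a functional assay on HEK293 cells for agonist activity at probable G-protein coupled receptor 27 (Homo sapiens), read by a luciferase reporter and beta-arrestin recruitment, with a stated time of 10 min (a higher number here means a larger maximal response, a lower number a smaller maximal response), compound 1 `Cc1cc(Br)ccc1C(=O)Nc1ccc(S(=O)(=O)Nc2ccccc2)cc1` gives 103%. Compound 2 `O=C(Nc1ccc(S(=O)(=O)Nc2ccccc2)cc1)c1cc(F)c(Cl)cc1F` gives 37% in this assay, and compound 3 `N#Cc1ccc(C(=O)Nc2ccc(S(=O)(=O)Nc3ccccc3)cc2)c(F)c1` gives 29%. Compound 3 thus holds the lowest of the three numbers, but its gap to compound 2 lies within the scatter. Both large steps leave the 4-bromo-2-methylphenyl: a number 66 percentage points lower from compound 1 to compound 2 (beyond the scatter) and a number 74 percentage points lower from compound 1 to compound 3 (beyond the scatter). Between the two remaining aryls, a number 8 percentage points lower from compound 2 to compound 3 (within the scatter). The next compound, compound 4 `O=C(Nc1ccc(S(=O)(=O)Nc2ccccc2)cc1)c1ccc(Cl)cc1Cl`, differs from compound 3 as follows: 2,4-dichlorophenyl in place of 4-cyano-2-fluorophenyl on a carbonyl carbon. For the measured compounds named here, no measured step covers this exact exchange; the nearest comparison is compound 2, whose aryl likewise carries chlorine and no nitrile, and whose value 37% sits close to that of compound 3. Compound 4 is therefore expected to remain in the same low band, with an expected step of a number 16 percentage points higher from compound 3 to compound 4 (beyond the scatter). The estimate for compound 4 in this assay is 45%, ranging from 20% to 80%.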

Compound 4, largest response reached (Emax), in percent of the reference or control that the assay uses: 100%
For compound 4 the middle estimate is 55 percentage points below the measured one; the whole stated range lies below it.
By their numbers in this assay, from the lowest: compounds 3 and 2 (each within the scatter of the next); then compounds 4 and 1 (each within the scatter of the next).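

In this assay the 4-bromo-2-methylphenyl is no longer the only aryl on this carbonyl carbon that gives a large maximal response, as a number 3 percentage points lower from compound 1 to compound 4 (within the scatter) shows with 2,4-dichlorophenyl in its place. Chlorine on the aryl does not by itself place a compound in the upper band, as a number 63 percentage points higher from compound 2 to compound 4 (beyond the scatter) separates two chlorine-bearing aryls, and a number 71 percentage points higher from compound 3 to compound 4 (beyond the scatter) leads from the nitrile-bearing aryl to that same upper band. The compounds thus fall into two bands, compounds 1 and 4 above compounds 2 and 3, and no measurement at hand accounts for this split.

Both lower compounds carry fluorine and neither upper compound does, but the aryls shown differ in more than that one feature. Where a 4-bromo-2-fluorophenyl or an unsubstituted phenyl would fall remains open.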